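This account rests on a few compounds, and the source may have more. Where it says the series, first, only, none or still open, it means among the compounds named here.

Measured so far:
compound 1, `CC(C)=CCCC1=CC[C@H](C(=O)NCCC(=O)O)[C@@H](c2ccccc2)C1`: > 23000 nM
compound 2, `CC(C)=CCCC1=CC[C@@H](C(=O)Nc2ccc(C(=O)O)cc2)[C@H](c2ccccc2)C1`: 2200 nM

Both compounds share one core and differ only in the group carried on the amide-type nitrogen. In an assay on isolated protein for inhibition of Apoptosis regulator Bcl-2 (Homo sapiens), read by fluorescence polarization, with stated times of 5 min and 10 min (a lower number here means a stronger inhibitor, a higher number a weaker inhibitor), compound 2 gives 2200 nM, which is the only true number among the two readings shown. For compound 1 the reading > 23000 nM is a limit of the assay, not a number. Going by the values given here, that is the limit of > 23000 nM in this assay, at which 1 of the 2 values shown sits, so compound 2 stands alone as the one compound with a measured inhibition constant.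

Compound 3, `COC(=O)CCNC(=O)[C@@H]1CC=C(CCC=C(C)C)C[C@H]1c1ccccc1`, has not yet been measured. It differs from compound 2 in one place: 2-(methoxycarbonyl)ethyl in place of 4-carboxyphenyl on an amide-type nitrogen. The step from compound 2 to compound 3 is expected to run towards weaker inhibition, by a 14-fold higher number from compound 2 to compound 3 (1.13 log units; beyond the scatter), well beyond the usual scatter. This expectation rests on compound 1, which gives the limit > 23000 nM. Compound 3 is therefore estimated at 30000 nM, with a likely range from 8000 nM to 120000 nM, and a real chance that only a limit is reported.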

Compound 3, inhibition constant: > 23000 nM
Compound 3: no number, only a limit; the forecaster's own chance of this, stated with the estimate: 70%; the middle value lies beyond the limit too.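

In this assay, going by these compounds alone, replacing 4-carboxyphenyl with 2-(methoxycarbonyl)ethyl on the amide-type nitrogen gives an at least 10-fold higher number from compound 2 to compound 3 (1.01 log units; beyond the scatter) and provides the first step that can be read at this position, showing that this group can change the reading by a large margin. Compound 3 gives > 23000 nM, which is a limit of the assay and not a number. Going by these compounds, the step therefore marks only the smallest size the change could have, and its true size remains unknown because compound 3 sits at the limit, as does one other compound: the limit of > 23000 nM in this assay, at which 2 of the 3 values shown sit.

The change removes the six-membered aromatic ring and the carboxylic acid of 4-carboxyphenyl together, and it also replaces them with a chain ending in a methyl ester, so the compounds shown cannot tell which of these features accounts for the step. A plain phenyl group or a 4-aminophenyl group on the same nitrogen would help separate the role of the ring from that of the carboxylic acid, while no further step can be read among the compounds shown.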